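The source may report more compounds than this note shows. Statements on the series, on what has been measured and on what is new or still open speak of the compounds shown alone.

Measured compounds:
compound 1, `COc1ccc(CN2CCC(C(=O)Nc3ccc(CNc4nc(N(C)C)nc5cc(C)ccc45)cc3)CC2)cc1`
compound 2, `CCNc1nc(NCc2ccc(NC(=O)C3CCN(Cc4ccccc4)CC3)cc2)c2ccc(C)cc2n1`

In a functional assay on SV5A8 cells (Homo sapiens) for cytotoxicity (a higher number here means a weaker inhibitor, a lower number a stronger inhibitor), compound 1 gives only > 6180 nM, which is a limit of the assay and not a number. Compound 2 likewise stops at > 2140 nM, again a limit. Among the measured compounds shown here, no step between measured compounds is available, so the two values show only that both compounds sit at limits the limit of > 2140 nM in this assay, at which 1 of the 2 values shown sits (the limit of > 6180 nM in this assay, at which 1 of the 2 values shown sits). Compound 3, `Cc1ccc2c(NCc3ccc(NC(=O)C4CCN(C)CC4)cc3)nc(N(C)C)nc2c1`, carries hydrogen in place of 4-methoxyphenyl on a saturated chain carbon bound to an amine nitrogen in a ring. For the measured compounds named here, with no measured step to size this change, no movement beyond the scatter is expected. Compound 3 is expected to give 8000 nM, estimated between 3000 nM and 25000 nM. The estimated step is a step that the limit leaves unreadable from compound 1 to compound 3, most likely reported again as a limit.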

Compound 3, half-maximal inhibitory concentration: > 17300 nM
Compound 3 gave a limit, no number (the forecaster's own chance of this, stated with the estimate: 70%); middle value at least 2.1-fold (0.33 log units) away from the limit.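

Compound 1 and compound 3 both stand at limits, not numbers, and the step between them cannot be read. The compounds shown leave open whether 4-methoxybenzyl to methyl changes the read-out at all.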